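Aryl change at the short-lived end of the series

The source may hold more compounds than are shown below. What is called first, only, known or untested is meant among the compounds shown, and "the series" means these compounds.

Measured in an ADME assay on microsomes from liver (Rattus norvegicus) for metabolic stability, read by LC-MS, using NADPH, at 37 degrees C; on this read-out lower numbers stand for a shorter-lived compound and higher numbers for a longer-lived compound:
compound 1 `Cc1oc(-c2ccc(Cl)cc2)nc1CN1CCC(C(=O)NCCCN2C[C@H](C)C[C@H](C)C2)CC1`: > 0.5 h (a limit)
compound 2 `COc1cccc(Cl)c1-c1nc(CN2CCC(C(=O)NCCCN3C[C@H](C)C[C@H](C)C3)CC2)c(C)o1`: 0.055 h

The entry for compound 1 is a limit of the assay and not a number. Among the measured compounds shown here, compound 2 holds the only true number so far, 0.055 h, and it is the shorter-lived of the pair. For the measured compounds named here, the one measured step is an at least 9.0-fold lower number from compound 1 to compound 2 (0.95 log units; beyond the scatter). From the compounds shown here alone, its full size stays open, with the limit of > 0.5 h in this assay, at which 1 of the 2 values shown sits.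

Compound 3 `CCc1ccccc1-c1nc(CN2CCC(C(=O)NCCCN3C[C@H](C)C[C@H](C)C3)CC2)c(C)o1` changes the same place again, with 2-ethylphenyl in place of 2-chloro-6-methoxyphenyl on an aromatic carbon. Going by the values given here, no measured compound carries 2-ethylphenyl, so the only guide is the step at this place, an at least 9.0-fold lower number from compound 1 to compound 2 (0.95 log units; beyond the scatter). That step shows that compound 2 can differ widely from compound 1 through this group alone, but it gives no direction for the new group. A small upward lean is expected in this assay, not clearly beyond the scatter: a 1.6-fold higher number from compound 2 to compound 3 (0.21 log units; within the scatter). The range is left wider on the upper side. For compound 3 the expected half-life is 0.09 h, with an estimated range of 0.03 h to 0.35 h.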

Compound 3, half-life: 0.283 h
For compound 3 the middle estimate is 3.1-fold (0.50 log units) below the measured one, within the range that was stated.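

In this assay, 2-ethylphenyl in place of 2-chloro-6-methoxyphenyl gives a 5.1-fold higher number from compound 2 to compound 3 (0.71 log units; beyond the scatter), so the short half-life of compound 2 does not follow simply from leaving 4-chlorophenyl at this place. The earlier pair showed only a drop on moving away from 4-chlorophenyl, whereas this step shows that the number can also rise again with a different substituted phenyl group on the same aromatic carbon. Against 4-chlorophenyl, the change to 2-ethylphenyl gives an at least 1.7-fold lower number from compound 1 to compound 3 (0.24 log units; that floor lies within the scatter), and as that floor lies within the scatter, it does not establish that 2-ethylphenyl shortens the half-life.

From the compounds shown here alone, the step from compound 2 to compound 3 removes the chlorine and the methoxy group and brings in the ethyl group in a single change, so the share of each stays open, and 2-chlorophenyl and 2-methoxyphenyl would be the groups to separate them. The entry for compound 1 is a limit, so the true size of both steps from that compound stays open: the limit of > 0.5 h in this assay, at which 1 of the 3 values shown sits.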